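This account rests on a few compounds, and the source may have more. Where it says the series, first, only, none or still open, it means among the compounds named here.

Compound 1 `C/C=C1/[C@H](O[C@@H]2O[C@H](CO)[C@@H](O)[C@H](O)[C@H]2O)OC=C(C(=O)OC)[C@H]1CC(=O)OCc1ccco1` was tested in a functional assay on SK-BR-3 cells (Homo sapiens) for antiproliferative activity, read by MTT assay, with a stated time of 72 h; on this read-out lower numbers stand for stronger inhibition and higher numbers for weaker inhibition. In this assay compound 1 gives > 15000 nM, which is a limit of the assay and not a number, so compound 1 stands at the edge of what the assay can report. Compound 2 `C#CCOC(=O)C[C@@H]1C(C(=O)OC)=CO[C@@H](O[C@@H]2O[C@H](COC(C)=O)[C@@H](OC(C)=O)[C@H](OC(C)=O)[C@H]2OC(C)=O)/C1=C/C` was tested in the same way. In this assay compound 2 gives > 15000 nM, again a limit of the assay. Among the compounds with values here, both known values sit at the same limit (the limit of > 15000 nM in this assay, at which 2 of the 2 values shown sit), so no measured step exists and nothing shows how a change in the ester group moves the read-out. Compound 3 `C/C=C1/[C@H](O[C@@H]2O[C@H](CO)[C@@H](O)[C@H](O)[C@H]2O)OC=C(C(=O)OC)[C@H]1CC(=O)OCCc1ccc(OC)c(OC)c1` has not yet been measured. It differs from compound 1 in one place: 3,4-dimethoxybenzyl in place of furan-2-yl on a saturated chain carbon bound to an oxygen next to a carbonyl group. From two limits alone no size of step can be read. The expectation is that the step that the limit leaves unreadable from compound 1 to compound 3 is none beyond the scatter, with compound 3 most likely again reported as a limit. The estimate for compound 3 is 20000 nM, with a range from 5000 nM to 60000 nM.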

Compound 3, half-maximal inhibitory concentration: > 15000 nM
Compound 3 gave a limit, no number; the forecaster's own chance of this, stated with the estimate: 80%; the middle value does not contradict the limit.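

Compound 1 and compound 3 both end at a limit of the assay and not at a number, so no step between them can be read: the limit of > 15000 nM in this assay, at which 3 of the 3 values shown sit.

The compounds shown leave open whether any change in the ester group can give a measurable value in this assay.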